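The compounds below may be only part of what the source reports. "The series", "measured", "known", "first", "only" and "open" are said of these compounds alone.

Compound 1 `CCCC(=O)Nc1cccc(NC(=O)COc2ccc3c(=O)ccoc3c2)c1`: 1430 nM
Compound 2 `N#Cc1ccc(C(=O)Nc2cccc(NC(=O)COc3ccc4c(=O)ccoc4c3)c2)cc1`: 123 nM
Compound 3 `COC(=O)c1ccc(C(=O)Nc2cccc(NC(=O)COc3ccc4c(=O)ccoc4c3)c2)cc1`: 72 nM

In an assay on isolated protein for inhibition of Rho-associated protein kinase 1 (Homo sapiens), read by scintillation counting, radiometric assay and 33P incorporation, with a stated time of 40 min, in the presence of a further agent that is not named here (a higher number here means a weaker inhibitor, a lower number a stronger inhibitor), compound 3 has the lowest number of the three. Its gap to compound 2 lies within the scatter, so the two cannot be ordered, while a 20-fold lower number from compound 1 to compound 3 (1.30 log units; beyond the scatter) is clearly beyond it. Compound 4 `Cc1cc(C(=O)Nc2cccc(NC(=O)COc3ccc4c(=O)ccoc4c3)c2)no1` differs from compound 3 by 5-methyl-1,2-oxazol-3-yl in place of 4-(methoxycarbonyl)phenyl on a carbonyl carbon. Going by the values given here, the steps that bear on this are a 20-fold lower number from compound 1 to compound 3 (1.30 log units; beyond the scatter) and a 12-fold lower number from compound 1 to compound 2 (1.07 log units; beyond the scatter), both of which placed an aromatic ring on the carbonyl carbon in place of a chain, and a 1.7-fold lower number from compound 2 to compound 3 (0.23 log units; within the scatter), which swapped one aromatic substituent for another. Among the compounds with values here, no measured step exchanges a six-membered carbocycle for a five-membered heteroaromatic ring, so a smaller change than the chain-to-ring steps is expected, in no clear direction. Compound 4 is expected to give 150 nM, within 50 nM to 450 nM, which would be a 2.1-fold higher number from compound 3 to compound 4 (0.32 log units; beyond the scatter).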

Compound 4, half-maximal inhibitory concentration: 68 nM
Beside the measured number, compound 4's estimate is 2.2-fold (0.34 log units) above it; low and high end bracket the measured number.
By their numbers in this assay, from the lowest: compounds 4, 3 and 2 (each within the scatter of the next); then compound 1.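

On this carbonyl carbon, 5-methyl-1,2-oxazol-3-yl, a five-membered aromatic ring with 2 hetero atoms and fewer heavy atoms, stands in for the six-membered rings without a readable change: a 1.1-fold lower number from compound 3 to compound 4 (0.02 log units; within the scatter) and a 1.8-fold lower number from compound 2 to compound 4 (0.26 log units; within the scatter) both lie within the scatter. Likewise, a 21-fold lower number from compound 1 to compound 4 (1.32 log units; beyond the scatter) shows that the large step away from propyl does not require a six-membered aromatic ring of carbon. As far as these compounds go, whether the methyl on the new ring matters remains open, as does how an amine or a carboxylic acid on this carbonyl carbon would fare. Nothing available here explains why these rings read alike.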